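Swapping an ester acid group on a rearranged core

A few compounds are considered here, and "the series" means these few. Any claim that something is new, unique, unknown or untested is made for them only; others in the source may bear on it.

Measured compounds:
compound 1, `C#Cc1cccc(Nc2ncnc3cc(OCCOC(=O)c4ccccc4OC(C)=O)c(OCCOC)cc23)c1`: 1800 nM
compound 2, `C#Cc1cccc(Nc2ncnc3cc(OCCOC(=O)C(C)c4ccc(CC(C)C)cc4)c(OCCOC)cc23)c1`: 2200 nM
compound 3, `C#Cc1cccc(Nc2ncnc3cc(OCCOC)c(OCCOC(=O)c4ccccc4OC(C)=O)cc23)c1`: > 10000 nM

All three were tested in a functional assay on A-431 cells (Homo sapiens) for antiproliferative activity, read by CCK-8 assay, with a stated time of 72 h; on this read-out higher numbers stand for weaker inhibition and lower numbers for stronger inhibition. Compound 1 gives 1800 nM and compound 2 gives 2200 nM. The two differ in one place, (1-(4-isobutylphenyl)ethyl in place of 2-acetoxyphenyl on a carbonyl carbon), and the step is a 1.2-fold higher number from compound 1 to compound 2 (0.09 log units; within the scatter). Compound 3 returns only a limit in this assay, > 10000 nM; this is the limit of > 10000 nM in this assay, at which 1 of the 3 values shown sits, and no number stands behind it. Compound 3 is built from the same atoms as compound 1, joined differently, and the difference between the two cores is not broken down here.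

Compound 4, `C#Cc1cccc(Nc2ncnc3cc(OCCOC)c(OCCOC(=O)C(C)c4ccc(CC(C)C)cc4)cc23)c1`, has not yet been measured in this assay. It stands to compound 3 as compound 2 stands to compound 1: the change is 1-(4-isobutylphenyl)ethyl in place of 2-acetoxyphenyl on a carbonyl carbon, the same change, made at the same place.

The expectation for compound 4 rests on the measured pair: compound 1 to compound 2 moved by a 1.2-fold higher number from compound 1 to compound 2 (0.09 log units; within the scatter), and compound 3 sits at a limit. The expected step is therefore a step that the limit leaves unreadable from compound 3 to compound 4, small and uncertain in sign. For compound 4 the estimated value is 15000 nM. The expected range for compound 4 is estimated to run from 6000 nM to 40000 nM, and a further limit rather than a number is the likelier outcome.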

Compound 4, half-maximal inhibitory concentration: > 10000 nM
Compound 4 ended at the assay's limit; the forecaster's own chance of this, stated with the estimate: 70%; the middle value does not contradict the limit.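

In this assay, compound 3 and compound 4 both end at a limit of the assay rather than at a number, so no step can be read between them: the limit of > 10000 nM in this assay, at which 2 of the 4 values shown sit. The compounds shown leave open whether 1-(4-isobutylphenyl)ethyl in place of 2-acetoxyphenyl makes any difference on the core shared by compound 3 and compound 4.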